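The compounds below may be only part of what the source reports. "The series", "measured", "known", "first", "only" and "open" are said of these compounds alone.

Measured compounds:
- compound 1, `COc1cc(/C=C/C(=O)c2cccc(-n3cc(C(C)(C)O)nn3)c2)ccc1O` — 19800 nM
- compound 2, `COc1ccc(-c2cn(-c3cccc(C(=O)/C=C/c4ccc(O)c(OC)c4)c3)nn2)cc1` — 7900 nM
- compound 3, `COc1ccc(/C=C/C(=O)c2cccc(-n3cc(C(C)(C)O)nn3)c2)cc1O` — 17100 nM

In a functional assay on RAW264.7 cells (Mus musculus) for inhibition, with a stated time of 4 days (on this read-out higher numbers stand for weaker inhibition and lower numbers for stronger inhibition), compound 3 sits second highest of the three numbers. The nearest step is small, a 1.2-fold lower number from compound 1 to compound 3 (0.06 log units; within the scatter), so those two compounds cannot be told apart on this read-out. Compound 2 gives a clearly smaller number than compound 3, and that gap is beyond the scatter.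

Compound 4, `COc1ccc(/C=C/C(=O)c2cccc(-n3cc(-c4cc(F)cc(F)c4)nn3)c2)cc1O`, differs from compound 3 in one place: 3,5-difluorophenyl in place of 1-hydroxy-1-methylethyl on an aromatic carbon. Among the measured compounds shown here, one measured step bears on this. From compound 1 to compound 2 an aromatic ring also took the place of the 1-hydroxy-1-methylethyl group on the same aromatic carbon, and the result was a 2.5-fold lower number from compound 1 to compound 2 (0.40 log units; beyond the scatter). The ring entering compound 4 carries two fluorines rather than a methoxy group, so the earlier step is a guide rather than a copy. A modest drop in the number is therefore expected for compound 4, on the order of a 2.4-fold lower number from compound 3 to compound 4 (0.39 log units; beyond the scatter), with a wide range to allow for the different ring substituents. Compound 4 is estimated at 7000 nM, between 3000 nM and 16000 nM.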

Compound 4, half-maximal inhibitory concentration: 7140 nM
Beside the measured number, compound 4's estimate is 1.0-fold (0.01 log units) below it; the range from low to high includes it.
By their numbers in this assay, from the lowest: compounds 4 and 2 (each within the scatter of the next); then compounds 3 and 1 (each within the scatter of the next).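

In this assay, the swap of 1-hydroxy-1-methylethyl for an aromatic ring at this triazole-free position of the core now appears a second time, with a 2.4-fold lower number from compound 3 to compound 4 (0.38 log units; beyond the scatter) standing close in size to a 2.5-fold lower number from compound 1 to compound 2 (0.40 log units; beyond the scatter).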